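Notes on sulfonyl variation in the shared core series

The source may report more compounds than this note shows. Statements on the series, on what has been measured and on what is new or still open speak of the compounds shown alone.

Compound 1 `CCOC(=O)N1CCC(Oc2ncnc3c2CCN3c2ccc(S(C)(=O)=O)cc2F)CC1` gives 251 nM in a functional assay on CHO-K1 cells for agonist activity at Glucose-dependent insulinotropic receptor (Homo sapiens), read by a luciferase reporter, with a stated time of 5 h; on this read-out higher numbers stand for an effect only at larger amounts of compound and lower numbers for an effect already at smaller amounts.
Compound 2 `CCS(=O)(=O)N1CCC(Oc2ncnc3c2CCN3c2ccc(S(C)(=O)=O)cc2F)CC1` gives 1580 nM in this assay.
Compound 3 `CC(C)S(=O)(=O)N1CCC(Oc2ncnc3c2CCN3c2ccc(S(C)(=O)=O)cc2F)CC1` gives 1260 nM in this assay.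

Compound 3 stands second highest of the three numbers. Its nearest neighbour is compound 2, separated by a 1.3-fold lower number from compound 2 to compound 3 (0.10 log units; within the scatter), a gap within the scatter; the furthest is compound 1, separated by a 5.0-fold higher number from compound 1 to compound 3 (0.70 log units; beyond the scatter), which lies beyond it.

Compound 4 `CN(C)S(=O)(=O)N1CCC(Oc2ncnc3c2CCN3c2ccc(S(C)(=O)=O)cc2F)CC1` has not yet been measured. It differs from compound 3 by dimethylamino in place of isopropyl on a sulfonyl sulfur. Two kinds of measured step bear on this part of the shared core. Replacing the ethoxycarbonyl by a sulfonyl group gave a 6.3-fold higher number from compound 1 to compound 2 (0.80 log units; beyond the scatter) and a 5.0-fold higher number from compound 1 to compound 3 (0.70 log units; beyond the scatter), both beyond the scatter. Once the sulfonyl was in place, enlarging the alkyl gave a 1.3-fold lower number from compound 2 to compound 3 (0.10 log units; within the scatter), within the scatter. Among the measured compounds shown here, no measured pair exchanges a carbon for a nitrogen on the sulfonyl sulfur, so the direction of this change is open. Because a 1.3-fold lower number from compound 2 to compound 3 (0.10 log units; within the scatter) lay within the scatter and the sulfonyl itself is kept, the step of a 1.0-fold higher number from compound 3 to compound 4 (0.01 log units; within the scatter) is expected to stay within or near the scatter in this assay. Compound 4 is therefore estimated at 1300 nM, with a range from 500 nM to 3500 nM.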

Compound 4, half-maximal effective concentration: 398 nM
Beside the measured number, compound 4's estimate is 3.3-fold (0.51 log units) above it; measured number below the stated range.
By their numbers in this assay, from the lowest: compounds 1 and 4 (each within the scatter of the next); then compounds 3 and 2 (each within the scatter of the next).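

The atom on the sulfonyl sulfur matters in this assay: dimethylamino in place of isopropyl gives a 3.2-fold lower number from compound 3 to compound 4 (0.50 log units; beyond the scatter), and dimethylamino in place of ethyl gives a 4.0-fold lower number from compound 2 to compound 4 (0.60 log units; beyond the scatter), both beyond the scatter, whereas the alkyl change alone gave a 1.3-fold lower number from compound 2 to compound 3 (0.10 log units; within the scatter), within it. The sulfonyl on the amine nitrogen in the ring therefore does not by itself go with the higher numbers of compound 2 and compound 3, since compound 4 keeps it and the exchange of ethoxycarbonyl for dimethylsulfamoyl gives a 1.6-fold higher number from compound 1 to compound 4 (0.20 log units; within the scatter), within the scatter, leaving these two groups not separated in this read-out. Nothing supplied here accounts for the effect of dimethylamino on the sulfonyl sulfur.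

Dimethylamino is the only nitrogen group shown on the sulfonyl sulfur, so it remains open whether methylamino, pyrrolidine or morpholine there would track compound 4 or stay with compound 2 and compound 3. Also open, going by these compounds, is how a dimethylcarbamoyl group on the amine nitrogen in the ring would compare with ethoxycarbonyl and dimethylsulfamoyl.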